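Swapping a Phenol for Fluorine on a Benzothiazole Enaminone

The source may report more compounds than this note shows. Statements on the series, on what has been measured and on what is new or still open speak of the compounds shown alone.

Measured so far in a functional assay on MDA-MB-231 cells (Homo sapiens) for antiproliferative activity, read by sulforhodamine B assay, with a stated time of 48 h; a lower number here means a stronger inhibitor, a higher number a weaker inhibitor:
- compound 1 `COc1ccc2nc(-c3ccc(N/C=C\C(=O)c4ccc(OC)c(O)c4)c(C)c3)sc2c1` gives 14000 nM
- compound 2 `COc1cc(OC)c2sc(-c3ccc(N/C=C\C(=O)c4ccc(OC)c(O)c4)c(C)c3)nc2c1` gives 3100 nM

Of the compounds shown here, two sharing the same core have been tested. Compound 1 stands at the higher of the two numbers, so it is the weaker inhibitor of the pair. Compound 2 gives a lower number, and this gap lies beyond the usual scatter of repeated measurements, so compound 2 is the stronger of the two. Among the measured compounds shown here, no pair of compounds differing in a single place has been measured, so no directly comparable step is known yet.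

Compound 3 `COc1ccc2nc(-c3ccc(N/C=C\C(=O)c4ccc(OC)c(F)c4)c(C)c3)sc2c1` has not been measured. It differs from compound 1 by fluoro in place of hydroxy on an aromatic carbon. Nothing measured here shows how this exchange acts, so the expectation rests on the value of compound 1 alone. The step of a 1.4-fold higher number from compound 1 to compound 3 (0.15 log units; within the scatter) is expected to be small, if anything a slight move toward weaker inhibition, and may fall within the scatter. For compound 3 the estimated result in this assay is 20000 nM, within a range of 6000 nM to 60000 nM.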

Compound 3, half-maximal inhibitory concentration: 2000 nM
The estimate for compound 3 lay 10-fold (1.00 log units) above the measured number; the whole stated range lies above it.
By their numbers in this assay, from the lowest: compounds 3 and 2 (each within the scatter of the next); then compound 1.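

The hydroxy group on the 3-hydroxy-4-methoxyphenyl ring turns out not to be required for activity on the core of compound 1: in this assay the exchange for fluoro gives a 7.0-fold lower number from compound 1 to compound 3 (0.85 log units; beyond the scatter) and so moves toward stronger inhibition, a step beyond the scatter. Among the compounds shown here, this is the first comparison here that changes a single place, and it isolates this aromatic carbon, ortho to a methoxy group, as a position where the substituent matters, since a hydroxy group counted as one hydrogen-bond donor and one hydrogen-bond acceptor gives way to a fluoro group counted as neither and the number drops. Nothing measured alongside these numbers accounts for the size or direction of this step, so its cause remains unknown.

Still open, on these data alone, is whether the same exchange would move the number in the same direction on the core of compound 2, since this single pair speaks only for the core of compound 1. As far as these compounds go, it is also open how a plain hydrogen, a chlorine atom, an amine or a nitrile at this position would compare with fluoro and hydroxy.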